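The compounds below may be only part of what the source reports. "The series", "measured", "known", "first", "only" and "open" are said of these compounds alone.

Measured compounds:
Compound 1, `Cc1cccc(-c2ccc(N(C[C@@H](N)CC(C)C)C(=O)[C@@H]3C[C@H]3c3ccccc3)cc2)c1`: 1200 nM
Compound 2, `Cc1ccccc1-c1ccc(N(C[C@@H](N)CC(C)C)C(=O)[C@@H]2C[C@H]2c2ccccc2)cc1`: 3400 nM
Compound 3, `CC(C)C[C@H](N)CN(C(=O)[C@@H]1C[C@H]1c1ccccc1)c1ccc(-c2cccc(C#N)c2)cc1`: 4500 nM

All three were tested in a functional assay for agonist activity at G protein-coupled receptor 88 (Homo sapiens), read by HTRF and cAMP accumulation; a lower number here means that less compound is needed, a higher number that more compound is needed for the effect. Compound 3 stands apart from compound 1 by a 3.8-fold higher number from compound 1 to compound 3 (0.57 log units; beyond the scatter), whereas a 1.3-fold higher number from compound 2 to compound 3 (0.12 log units; within the scatter) lies within the scatter, so compound 2 and compound 3 cannot be told apart on these numbers.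

Compound 4, `CC(C)C[C@H](N)CN(C(=O)[C@@H]1C[C@H]1c1ccccc1)c1ccc(-c2ccc(Cl)cc2)cc1`, has not yet been measured. It differs from compound 3 in one place: 4-chlorophenyl in place of 3-cyanophenyl on an aromatic carbon. The earlier steps shown here all concern a methyl group or a nitrile on the same aromatic ring: a 2.8-fold higher number from compound 1 to compound 2 (0.45 log units; beyond the scatter), a 3.8-fold higher number from compound 1 to compound 3 (0.57 log units; beyond the scatter) and a 1.3-fold higher number from compound 2 to compound 3 (0.12 log units; within the scatter). None of them involves a chlorine, so they give only the general spread of this series, which is modest. On that basis a change of a modest size in either direction is expected in this assay, most likely landing within the range of the three measured compounds. For compound 4 the expected value is 2500 nM, with a range from 700 nM to 8000 nM, which would mean a step of a 1.8-fold lower number from compound 3 to compound 4 (0.26 log units; within the scatter).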

Compound 4, half-maximal effective concentration: 640 nM
Compound 4: the middle estimate sits 3.9-fold (0.59 log units) above what was measured; the measured number lies below the stated range.
By their numbers in this assay, from the lowest: compounds 4 and 1 (each within the scatter of the next); then compounds 2 and 3 (each within the scatter of the next).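

In this assay, among these compounds, 4-chlorophenyl gives a 7.0-fold lower number from compound 3 to compound 4 (0.85 log units; beyond the scatter) and a 5.3-fold lower number from compound 2 to compound 4 (0.73 log units; beyond the scatter), both larger than any step among the earlier compounds, so this position can shift the number further than they showed. Against the best of the earlier compounds the picture differs: a 1.9-fold lower number from compound 1 to compound 4 (0.27 log units; within the scatter) lies within the scatter, so 4-chlorophenyl and 3-methylphenyl cannot be told apart, and two different groups on this ring give comparable numbers. No measurement shown here accounts for these steps.

The 4-chlorophenyl group differs from each of the other groups in both the substituent and its place on the ring, so the effect of the chlorine itself cannot be separated from the effect of its place. As far as these compounds go, how a bromine, a methoxy group or an unsubstituted phenyl ring would behave here also stays open.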